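A few compounds are considered here, and "the series" means these few. Any claim that something is new, unique, unknown or untested is made for them only; others in the source may bear on it.

Of the compounds shown here, three of the shared core have been measured in a functional assay on HepG2 cells (Homo sapiens) for cytotoxicity, read by MTT assay, with a stated time of 72 h; on this read-out lower numbers stand for stronger inhibition and higher numbers for weaker inhibition. Compound 1 `COc1ccc(C(=O)NC[C@H]2c3[nH]c4ccccc4c3C[C@H]3[C@H]4c5[nH]c6ccccc6c5C[C@@H]([C@H](C#N)N23)N4C)cc1` gives 310 nM. Compound 2 `CN1[C@@H]2c3[nH]c4ccccc4c3C[C@H]1[C@H](C#N)N1[C@@H](CNC(=O)c3ccc(F)cc3)c3[nH]c4ccccc4c3C[C@@H]21` gives 210 nM, and compound 3 `CN1[C@@H]2c3[nH]c4ccccc4c3C[C@H]1[C@H](C#N)N1[C@@H](CNC(=O)c3cc4ccccc4[nH]3)c3[nH]c4ccccc4c3C[C@@H]21` gives 440 nM. Compound 2 holds the lowest of the three numbers: the step of a 1.5-fold lower number from compound 1 to compound 2 (0.17 log units; within the scatter) lies within the scatter, while the step of a 2.1-fold higher number from compound 2 to compound 3 (0.32 log units; beyond the scatter) is the only one of the set beyond it.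

Compound 4 `CN1[C@@H]2c3[nH]c4ccccc4c3C[C@H]1[C@H](C#N)N1[C@@H](CNC(=O)/C=C/c3cccc(C(F)(F)F)c3)c3[nH]c4ccccc4c3C[C@@H]21` differs from compound 2 on the carbonyl carbon: 2-(3-(trifluoromethyl)phenyl)ethenyl in place of 4-fluorophenyl on a carbonyl carbon. Going by the values given here, the steps that bear on this are the three that exchange the group on the carbonyl carbon, a 1.5-fold lower number from compound 1 to compound 2 (0.17 log units; within the scatter) and a 1.4-fold higher number from compound 1 to compound 3 (0.15 log units; within the scatter), both within the scatter, and a 2.1-fold higher number from compound 2 to compound 3 (0.32 log units; beyond the scatter), modest. Every exchange so far has moved the number only a little, so for compound 4 in this assay a small shift toward a higher number is expected, of roughly the size seen for compound 3 and not beyond it by much. The estimate for compound 4 is 350 nM, within 150 nM to 800 nM, a step of a 1.7-fold higher number from compound 2 to compound 4 (0.22 log units; within the scatter) that is expected to sit close to the edge of the scatter.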

Compound 4, half-maximal inhibitory concentration: 540 nM
Compound 4: middle estimate off by 1.5-fold (0.19 log units), on the low side, and the stated range covers the measured number.
By their numbers in this assay, from the lowest: compounds 2, 1, 3 and 4 (each within the scatter of the next, the first and the last beyond it).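

In this assay, the exchange on the carbonyl carbon for 2-(3-(trifluoromethyl)phenyl)ethenyl, with 12 heavy atoms and a double bond outside the aromatic ring, gives a second step beyond the scatter from compound 2 (a 2.6-fold higher number from compound 2 to compound 4 (0.41 log units; beyond the scatter)). The same group cannot be told apart from 1H-indol-2-yl (a 1.2-fold higher number from compound 3 to compound 4 (0.09 log units; within the scatter)) or from 4-methoxyphenyl (a 1.7-fold higher number from compound 1 to compound 4 (0.24 log units; within the scatter)), so this larger group with its ethenyl link keeps compound 4 within the scatter of compounds 1 and 3, and only compound 2 stands apart from it. Nothing on hand gives a reason for these differences.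

From the compounds shown here alone, compound 4 changes the ethenyl link and the ring substituent together, so the share of each stays open. Also open, going by these compounds, is how an amine, a carboxylic acid or a saturated alkyl chain on the carbonyl carbon would read in this assay.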